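From pyrrolidin-1-yl to piperidin-1-yl on a shared core

A few compounds are considered here, and "the series" means these few. Any claim that something is new, unique, unknown or untested is made for them only; others in the source may bear on it.

In a functional assay on MES-SA cells (Homo sapiens) for inhibition, with a stated time of 72 h (on this read-out lower numbers stand for stronger inhibition and higher numbers for weaker inhibition), compound 2 `COCc1cc(CN2CCCC2)c(O)c2ncccc12` gives 11000 nM, and compound 3 `CCOCc1cc(CN2CCCC2)c(O)c2ncccc12` gives 8510 nM. These two differ by a methyl in place of hydrogen on a saturated chain carbon bound to an oxygen on a saturated carbon. The step, a 1.3-fold lower number from compound 2 to compound 3 (0.11 log units; within the scatter), stays within the scatter, so compound 3 stands level with its nearest neighbour.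

Compound 4 `CCOCc1cc(CN2CCCCC2)c(O)c2ncccc12` keeps the rest of compound 3 and changes one group: piperidin-1-yl in place of pyrrolidin-1-yl on a saturated chain carbon bound to an aromatic carbon. In words, piperidin-1-yl sits in place of pyrrolidin-1-yl on a saturated chain carbon bound to an aromatic carbon.

Going by the values given here, no measured step makes this exact change. Among the compounds with values here, the one measured step lies at a different place on the molecule, so it says little here. The nearest clue is compound 1 `Oc1c(CN2CCCCC2)ccc2cccnc12`, which already carries piperidin-1-yl but also differs from compound 3 in a second place. In this assay, compound 1 at 5210 nM; 5130 nM (2 entries) and compound 3 at 8510 nM give no sign of a large shift.

The expected change is therefore no more than the scatter, a 1.1-fold lower number from compound 3 to compound 4 (0.05 log units; within the scatter). For compound 4 the estimated value is 7500 nM, with an expected range from 3500 nM to 15000 nM.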

Compound 4, half-maximal inhibitory concentration: 8710 nM
Compound 4: middle estimate off by 1.2-fold (0.06 log units), on the low side; the range from low to high includes it.
By their numbers in this assay, from the lowest: compounds 3, 4 and 2 (each within the scatter of the next).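

Going by these compounds alone, until now, the only measured step lay at a different place on the molecule, so nothing had been read for a change in the ring itself. Here, piperidin-1-yl replaces pyrrolidin-1-yl on a saturated chain carbon bound to an aromatic carbon, adding one ring carbon, and this assay gives a 1.0-fold higher number from compound 3 to compound 4 (0.01 log units; within the scatter), so this single pair shows no measurable difference between the two rings at this place. Repeat readings of one compound give a sense of how closely two numbers can agree in this assay: the several entries of compound 1 in this assay, 5210 nM; 5130 nM (2 entries)

The compounds shown carry only these two saturated rings at this place, so it remains open whether a morpholine ring, a dimethylamino group or an open-chain amine would also leave the number level. From the compounds shown here alone, it also remains open whether the same swap would read the same way on other versions of the shared core, such as the methoxymethyl-bearing compound 2, since the comparison rests on one pair alone.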